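A 4-methylpiperazin-1-yl group on the chain of compound 3

The compounds below may be only part of what the source reports. "The series", "measured", "known", "first", "only" and "open" are said of these compounds alone.

Compound 1 `COc1ncc(-c2ccc3nc(NC(=O)NCC(=O)N4CCCCC4)nn3c2)cc1NS(=O)(=O)c1ccc(F)cc1`: 130 nM
Compound 2 `COc1ncc(-c2ccc3nc(NC(=O)NCCN4CCCC4)nn3c2)cc1NS(=O)(=O)c1ccc(F)cc1`: 230 nM
Compound 3 `CCCNC(=O)Nc1nc2ccc(-c3cnc(OC)c(NS(=O)(=O)c4ccc(F)cc4)c3)cn2n1`: 150 nM

In a functional assay on HCT-116 cells (Homo sapiens) for cytotoxicity, read by MTT assay, with a stated time of 72 h (a higher number here means a weaker inhibitor, a lower number a stronger inhibitor), compound 3 gives 150 nM, which lies within the scatter of both other compounds. The steps to it are a 1.2-fold higher number from compound 1 to compound 3 (0.06 log units; within the scatter) and a 1.5-fold lower number from compound 2 to compound 3 (0.19 log units; within the scatter).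

Compound 4 `COc1ncc(-c2ccc3nc(NC(=O)NCCN4CCN(C)CC4)nn3c2)cc1NS(=O)(=O)c1ccc(F)cc1` has not yet been measured. It differs from compound 3 as follows: 4-methylpiperazin-1-yl in place of methyl on a saturated chain carbon, two bonds along the chain from an amide-type nitrogen. Thus 4-methylpiperazin-1-yl stands in place of methyl on a saturated chain carbon, two bonds along the chain from an amide-type nitrogen.

The closest measured comparison is the step involving compound 2, which carries pyrrolidin-1-yl at this place: a 1.5-fold lower number from compound 2 to compound 3 (0.19 log units; within the scatter). The other change of chain end, a 1.8-fold higher number from compound 1 to compound 2 (0.25 log units; within the scatter), also stayed within the scatter. Going by the values given here, no measured compound carries 4-methylpiperazin-1-yl, so this expectation rests on only three compounds.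

No step beyond the scatter is therefore expected, and the estimated step is a 1.3-fold higher number from compound 3 to compound 4 (0.10 log units; within the scatter). Compound 4 is expected at 190 nM, with an estimated range of 90 nM to 400 nM.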

Compound 4, half-maximal inhibitory concentration: 260 nM
Beside the measured number, compound 4's estimate is 1.4-fold (0.14 log units) below it, within the range that was stated.
By their numbers in this assay, from the lowest: compounds 1, 3, 2 and 4 (each within the scatter of the next).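

In this assay, the place on a saturated chain carbon, two bonds along the chain from an amide-type nitrogen, also takes 4-methylpiperazin-1-yl, with its six-membered non-aromatic ring holding 2 hetero atoms, without a step beyond the scatter (a 1.7-fold higher number from compound 3 to compound 4 (0.24 log units; within the scatter); a 1.1-fold higher number from compound 2 to compound 4 (0.05 log units; within the scatter)). Even the largest step among the four compounds (a 2.0-fold higher number from compound 1 to compound 4 (0.30 log units; within the scatter)) stays within the scatter, so the chain ends shown so far, from small ethyl-derived propyl to the ring-bearing amines and the piperidine amide, cannot be told apart in this read-out. Nothing available explains this result.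

Going by these compounds, whether a chain end carrying a carboxylic acid, a morpholine ring or a longer chain would leave the scatter stays open. Also open, on these data alone, is whether replacing the fluorine on the sulfonyl-bound ring of the shared core would move the number further than any chain end does here.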